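A few compounds are considered here, and "the series" means these few. Any claim that something is new, unique, unknown or untested is made for them only; others in the source may bear on it.

Compound 1, with the structure `O=S(=O)(c1cc(F)cc(F)c1)c1cnc2cc(F)ccc2c1-c1ccc(Cl)cc1`, is the slowest-cleared of the three measured compounds in an ADME assay on microsomes from liver (Homo sapiens) for metabolic stability, tested at 2.5 uM (a higher number here means faster removal of the compound, a lower number slower removal), where compound 1 gives 0.03 mL/min. Compound 2, `COc1cccc(-c2c(S(=O)(=O)c3cc(F)cc(F)c3)cnc3cc(F)ccc23)c1`, gives 1.81 mL/min in this assay, and compound 3, `O=S(=O)(c1cc(F)cc(F)c1)c1cnc2cc(F)ccc2c1-c1cccc(Cl)c1`, gives 0.22 mL/min. The measured steps all alter the aryl group attached to the shared core: there is a 60-fold higher number from compound 1 to compound 2 (1.78 log units; beyond the scatter), a 7.3-fold higher number from compound 1 to compound 3 (0.87 log units; beyond the scatter), and an 8.2-fold lower number from compound 2 to compound 3 (0.92 log units; beyond the scatter).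

Compound 4, `O=S(=O)(c1cccc(F)c1)c1cnc2cc(F)ccc2c1-c1ccc(Cl)cc1`, is compound 1 with one change: hydrogen in place of fluoro on an aromatic carbon. This alteration sits on the other side of the molecule, on the 3,5-difluorophenyl attached to the sulfonyl, a part that none of the three measured compounds varies. So no measured step bears directly on it; the measured steps only show that this assay is sensitive to changes on the aryl group opposite, while saying nothing about the sulfonyl-bound ring. With no guidance from the data, the loss of a single fluoro is expected to bring at most a small shift, not clearly beyond the scatter, and compound 4 is estimated at 0.05 mL/min, in a range from 0.015 mL/min to 0.2 mL/min, so the expected step is a 1.7-fold higher number from compound 1 to compound 4 (0.22 log units; within the scatter).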

Compound 4, intrinsic clearance in a liver preparation (reported as CLH), per the amount of preparation that the assay uses: 0.98 mL/min
Compound 4: middle estimate off by 20-fold (1.29 log units), on the low side; the measured number lies above the stated range.
By their numbers in this assay, from the lowest: compound 1; then compound 3; then compounds 4 and 2 (each within the scatter of the next).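

In this assay, replacing a single fluoro with hydrogen, which turns the 3,5-difluorophenyl into a 3-fluorophenyl, gives a 33-fold higher number from compound 1 to compound 4 (1.51 log units; beyond the scatter) and so means much faster removal. This shows that the ring on the sulfonyl is far from a silent part of the molecule: one small change there produces a step also classed as large, like the change on the chlorophenyl group that gives a 60-fold higher number from compound 1 to compound 2 (1.78 log units; beyond the scatter) in the same assay. Both parts of compound 1 therefore respond in this assay, though nothing available explains why losing one fluoro has so much weight.

Going by these compounds, it remains open whether the remaining fluoro on this ring matters as much, and whether a chloro, a nitrile or an amine in the place of the lost fluoro would keep removal slow. On these data alone, it is equally open whether the same swap would have a step of this size on compound 2 or compound 3, whose aryl groups differ from that of compound 1.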